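Triazole series: nitro-bearing benzyl sulfide to be measured

The source may report more compounds than this note shows. Statements on the series, on what has been measured and on what is new or still open speak of the compounds shown alone.

Measured so far:
compound 1 `Fc1ccc(CSc2nnc(-c3ccncc3)n2-c2ccccc2)cc1` — 21100 nM
compound 2 `c1ccc(CSc2nnc(-c3ccncc3)n2-c2ccccc2)cc1` — 22400 nM

In a functional assay on MCF7 cells (Homo sapiens) for inhibition, read by MTT assay, with a stated time of 48 h (a higher number here means a weaker inhibitor, a lower number a stronger inhibitor), compound 1 gives 21100 nM, and compound 2 gives 22400 nM. The step of a 1.1-fold higher number from compound 1 to compound 2 (0.03 log units; within the scatter) places the two within the scatter of each other, so neither stands apart from the other on the numbers shown.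

Compound 3 `O=[N+]([O-])c1ccccc1CSc1nnc(-c2ccncc2)n1-c1ccccc1` is not yet measured. It differs from compound 1 by 2-nitrophenyl in place of 4-fluorophenyl on a saturated chain carbon bound to a sulfur. Among the measured compounds shown here, the only measured step, a 1.1-fold higher number from compound 1 to compound 2 (0.03 log units; within the scatter), concerns the same benzyl group but exchanges fluoro for hydrogen; nothing measured here exchanges one substituted phenyl for another, and nothing bears on a nitro group. For the measured compounds named here, with the one related step within the scatter, no movement beyond the scatter is expected in this assay for compound 3, although the lack of any precedent for the nitro group widens the range. Compound 3 is estimated at 20000 nM (range 7000 nM to 55000 nM), which means an expected step of a 1.1-fold lower number from compound 1 to compound 3 (0.02 log units; within the scatter).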

Compound 3, half-maximal inhibitory concentration: > 50000 nM
Compound 3: no number, only a limit; the forecaster's own chance of this, stated with the estimate: 15%; middle value at least 2.5-fold (0.39 log units) away from the limit.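

At the saturated chain carbon bound to a sulfur, the substituent on the phenyl ring now makes a difference in this assay: nitro in place of hydrogen on an aromatic carbon gives an at least 2.2-fold higher number from compound 2 to compound 3 (0.34 log units; beyond the scatter), and 2-nitrophenyl in place of 4-fluorophenyl gives an at least 2.3-fold higher number from compound 1 to compound 3 (0.37 log units; beyond the scatter). These are the only steps shown that lie beyond the scatter, and both run toward a weaker inhibitor, whereas the exchange of fluoro for hydrogen does not separate compound 1 from compound 2. Compound 3 has a limit of the assay and not a number, so both steps set only a minimum size: the limit of > 50000 nM in this assay, at which 1 of the 3 values shown sits.

On these data alone, how far compound 3 lies past that limit stays open. An amine or a carboxylic acid on that aromatic carbon would show whether the weaker result belongs to the nitro group alone.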